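Pyrazole substituents from compound 2 to compound 4

A few compounds are considered here, and "the series" means these few. Any claim that something is new, unique, unknown or untested is made for them only; others in the source may bear on it.

Measured in an ADME assay on microsomes from liver (Homo sapiens) for metabolic stability; on this read-out lower numbers stand for slow clearance and higher numbers for fast clearance:
compound 1 `CCCC(Oc1ccc(-n2cc(C(=O)N(C)C)cn2)cc1)c1ccc(C(=O)NCCC(=O)O)cc1`: < 13 mL/min/kg, a limit
compound 2 `CCCC(Oc1ccc(-n2cc(C(F)(F)F)c(C)n2)cc1)c1ccc(C(=O)NCCC(=O)O)cc1`: < 10 mL/min/kg, a limit
compound 3 `CC(C)(C)C(Oc1ccc(-n2cc(C(F)(F)F)cn2)cc1)c1ccc(C(=O)NCCC(=O)O)cc1`: 31 mL/min/kg

Compound 2 stands on a limit and not on a number: its reading in this assay is < 10 mL/min/kg. Compound 1 also stands on a limit. Among the measured compounds shown here, compound 3, at 31 mL/min/kg, holds the only actual number in the set.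

Still unmeasured is compound 4 `CCCC(Oc1ccc(-n2cc(C)cn2)cc1)c1ccc(C(=O)NCCC(=O)O)cc1`. Compound 4 carries 4-methyl-1H-pyrazol-1-yl in place of 3-methyl-4-(trifluoromethyl)-1H-pyrazol-1-yl on an aromatic carbon, para to a large group (4-methyl-1H-pyrazol-1-yl in place of 3-methyl-4-(trifluoromethyl)-1H-pyrazol-1-yl on an aromatic carbon). The rest of compound 2 stays unchanged.

For the measured compounds named here, one measured step bears on this place: a step that the two limits leave unreadable from compound 1 to compound 2. Going by the values given here, with a limit at each end, it has no readable size, so no measured step sets a size for the new change. The expectation rests on compound 1, whose reading of < 13 mL/min/kg is a limit.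

The expected change is an at least 1.2-fold higher number from compound 2 to compound 4 (0.07 log units; that floor lies within the scatter), and no shift beyond the usual scatter is expected. A reading that is again a limit would be no surprise. In this assay the estimate for compound 4 is 12 mL/min/kg, with an expected range of 6 mL/min/kg to 25 mL/min/kg.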

Compound 4, clearance: 16 mL/min/kg
For compound 4 the middle estimate is 1.3-fold (0.12 log units) below the measured one, within the range that was stated.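

Among the compounds shown here, with 4-methyl-1H-pyrazol-1-yl on the aromatic carbon para to a large group, compound 4 gives the first actual number on this core in this assay, and the step away from 3-methyl-4-(trifluoromethyl)-1H-pyrazol-1-yl is an at least 1.6-fold higher number from compound 2 to compound 4 (0.20 log units; that floor lies within the scatter). Methyl in place of dimethylcarbamoyl gives an at least 1.2-fold higher number from compound 1 to compound 4 (0.09 log units; that floor lies within the scatter), so both replacements now have a lower bound on their size, yet neither bound shows a shift beyond the scatter. The first of these steps can be stated only as a floor because compound 2 stands on a limit: the limit of < 10 mL/min/kg in this assay, at which 1 of the 4 values shown sits.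

On these data alone, how far the second step reaches also stays open because compound 1 stands on a limit: the limit of < 13 mL/min/kg in this assay, at which 1 of the 4 values shown sits. Also open is how the 1H-pyrazol-1-yl group would read in this assay with a nitrile or a primary amine in place of methyl on this core.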